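A few compounds are considered here, and "the series" means these few. Any claim that something is new, unique, unknown or untested is made for them only; others in the source may bear on it.

Measured compounds:
compound 1 `CCOC(=O)/C=C/c1ccncc1-c1ccc2c(cnn2C)c1` with 5030 nM
compound 2 `Cn1ncc2cc(-c3cnccc3/C=C/C(=O)O)ccc21` with > 10000 nM
compound 3 `CCOC(=O)/C=C/c1ccncc1-c1ccc2c(ccn2C)c1` with 1720 nM

In a functional assay on A549 cells (Homo sapiens) for inhibition, read by sulforhodamine B assay, with a stated time of 72 h (on this read-out lower numbers stand for stronger inhibition of growth and higher numbers for weaker inhibition of growth), compound 1 gives 5030 nM. For compound 2 this assay reports only a limit, > 10000 nM. Compound 3 gives 1720 nM, the lowest of the two numbers shown.

The change from compound 1 to compound 2 is hydrogen in place of ethyl on an oxygen next to a carbonyl group. It produced an at least 1.9-fold higher number from compound 1 to compound 2 (0.29 log units; that floor lies within the scatter); the step can only be stated as a floor because of the limit of > 10000 nM in this assay, at which 1 of the 3 values shown sits. The difference between the core of compound 1 and the core of compound 3 is not broken down here.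

Compound 4 `Cn1ccc2cc(-c3cnccc3/C=C/C(=O)O)ccc21` has not yet been measured. It differs from compound 3 by hydrogen in place of ethyl on an oxygen next to a carbonyl group, the same change as that from compound 1 to compound 2. Starting from compound 3, the same direction of movement is expected, so compound 4 is estimated to show a 3.5-fold higher number from compound 3 to compound 4 (0.54 log units; beyond the scatter) in this assay, resting on the step from compound 1 to compound 2. Compound 4 is therefore expected to give about 6000 nM, most likely between 2500 nM and 20000 nM.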

Compound 4, concentration for 50% growth inhibition: > 10000 nM
Compound 4 ended at the assay's limit; the forecaster's own chance of this, stated with the estimate: 35%; middle value at least 1.6-fold (0.22 log units) from the limit.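

In this assay, the change from ethoxycarbonyl to carboxy on the core of compound 3 gave an at least 5.8-fold higher number from compound 3 to compound 4 (0.76 log units; beyond the scatter), a step that lies beyond the scatter. This shows that the change can weaken growth inhibition clearly on this core, whereas on the core of compound 1 the carboxy compound also stands at a limit of the assay and the floor of its step stays within the scatter. It does not show that the change has the same size on both cores, nor that its size differs between them: the same change on two cores in this assay, an at least 1.9-fold higher number (0.29 log units; that floor lies within the scatter) from compound 1 to compound 2 and an at least 5.8-fold higher number (0.76 log units; beyond the scatter) from compound 3 to compound 4; the limit leaves it open whether they differ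

The compounds shown leave open whether the outcome depends on ethyl itself, since a methyl ester, a longer chain on the oxygen or an amide in place of the ester could behave differently on either core. As far as these compounds go, they also cover only these two cores, so whether the step carries over to a third core remains unknown.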